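Triazole aryl substituent swap: bromo to chloro

The source may report more compounds than this note shows. Statements on the series, on what has been measured and on what is new or still open speak of the compounds shown alone.

Measured compounds and values:
- compound 1 `C/C(=C\CC/C(C)=C/CC[C@@H]1[C@@]2(C)CCC(=O)C(C)(C)[C@H]2CC[C@@]1(C)O)CC/C=C(\C)C(=O)OCc1cn(-c2ccccc2Br)nn1`: > 150000 nM
- compound 2 `C/C(=C\CC/C(C)=C/CC[C@@H]1[C@@]2(C)CCC(=O)C(C)(C)[C@H]2CC[C@@]1(C)O)CC/C=C(\C)C(=O)OCc1cn(C[C@@H]2O[C@H](n3ccc(=O)[nH]c3=O)C[C@H]2O)nn1`: 28100 nM
- compound 3 `C/C(=C\CC/C(C)=C/CC[C@@H]1[C@@]2(C)CCC(=O)C(C)(C)[C@H]2CC[C@@]1(C)O)CC/C=C(\C)C(=O)OCc1cn(-c2cccc([N+](=O)[O-])c2)nn1`: > 150000 nM

In a functional assay on A549 cells (Homo sapiens) for antiproliferative activity, read by MTT assay, with a stated time of 48 h (on this read-out higher numbers stand for weaker inhibition and lower numbers for stronger inhibition), compound 1 returns only a limit, > 150000 nM. Compound 3 likewise returns only a limit, > 150000 nM. Among the measured compounds shown here, compound 2 is the one member with a number, giving 28100 nM in this assay. Compound 1 thus stands among the inactive members, at the limit where most of the series sits (the limit of > 150000 nM in this assay, at which 2 of the 3 values shown sit). For the measured compounds named here, the single one-change step, a step that the two limits leave unreadable from compound 1 to compound 3, runs between two limits and its size cannot be read.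

Compound 4 `C/C(=C\CC/C(C)=C/CC[C@@H]1[C@@]2(C)CCC(=O)C(C)(C)[C@H]2CC[C@@]1(C)O)CC/C=C(\C)C(=O)OCc1cn(-c2ccccc2Cl)nn1` differs from compound 1 as follows: chloro in place of bromo on an aromatic carbon. Going by the values given here, no measured step exchanges one halogen for another, so no step bears directly on this change. Among the compounds with values here, the only single-change comparison available is the unreadable step above, and the two aryl-bearing members both sit at the limit. A chloro-for-bromo exchange is a small change, and compound 4 is therefore expected to remain at or near the limit of this assay, with a number no higher from compound 1 to compound 4 (the limit leaves the size open) expected to be no step beyond scatter.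

Estimate for compound 4 in this assay: 150000 nM, with a range of 60000 nM to 300000 nM.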

Compound 4, half-maximal inhibitory concentration: > 150000 nM
Compound 4: no number, only a limit; the forecaster's own chance of this, stated with the estimate: 75%; the middle value lies on the limit itself.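

Compound 4 returns only a limit, > 150000 nM. No step from compound 1 or compound 3 to compound 4 can be read, and compound 4 joins the members at the limit: the limit of > 150000 nM in this assay, at which 3 of the 4 values shown sit.

The compounds shown leave open how much activity, if any, compound 1, compound 3 and compound 4 have, and whether exchanging bromo for chloro changes it.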